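A few compounds are considered here, and "the series" means these few. Any claim that something is new, unique, unknown or untested is made for them only; others in the source may bear on it.

Working notes on the series. In an ADME assay on A549 cells (Homo sapiens) for cytotoxicity, read by resazurin assay, with a stated time of 48 h (on this read-out lower numbers stand for higher toxicity in this test and higher numbers for lower toxicity in this test), compound 1 `CCCCCCC(C)Nc1ccc(NC(=O)c2cc(Cl)ccc2O)c(Cl)c1` gives 23500 nM with 1-methylheptyl on a nitrogen on an aromatic ring, compound 2 `O=C(Nc1ccc(NC2CCCCC2)cc1Cl)c1cc(Cl)ccc1O` gives 68300 nM with cyclohexyl there, and compound 3 `O=C(Nc1ccc(NCc2ccc(Cl)cc2)cc1Cl)c1cc(Cl)ccc1O` gives 59700 nM with 4-chlorobenzyl there. Compound 3 lies within the scatter of compound 2 and clear of compound 1 on the higher side.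

The next structure is compound 4 `O=C(Nc1ccc(NCc2ccc(Br)cc2)cc1Cl)c1cc(Cl)ccc1O`. Its change from compound 3 is bromo in place of chloro on an aromatic carbon and reads bromo in place of chloro on an aromatic carbon, para to a large group, or 4-bromobenzyl in place of 4-chlorobenzyl.

Going by the values given here, no measured step touches this halogen. The nearest steps replace the whole group on that nitrogen: a 2.9-fold higher number from compound 1 to compound 2 (0.46 log units; beyond the scatter) and a 2.5-fold higher number from compound 1 to compound 3 (0.40 log units; beyond the scatter) are modest while a 1.1-fold lower number from compound 2 to compound 3 (0.06 log units; within the scatter) stays within the scatter. Resting on compound 3 at 59700 nM and on those modest steps, no step beyond the scatter is expected in this assay for this swap. The expected move is a 1.1-fold lower number from compound 3 to compound 4 (0.04 log units; within the scatter) and no direction can be argued from the data. For compound 4 the estimated value is 55000 nM with an expected range from 30000 nM to 95000 nM in this read-out.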

Compound 4, half-maximal cytotoxic concentration: 40900 nM
Compound 4: middle estimate off by 1.3-fold (0.13 log units), on the high side; the range from low to high includes it.
By their numbers in this assay, from the lowest: compounds 1, 4, 3 and 2 (each within the scatter of the next, the first and the last beyond it).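

In this assay, the swap of bromo for chloro on an aromatic carbon, para to a large group, gives a 1.5-fold lower number from compound 3 to compound 4 (0.16 log units; within the scatter), so this position tolerates the exchange of one halogen for the other without a step beyond the scatter. The swap does change how the benzyl compounds stand against the open-chain compound: the step to the 4-chlorobenzyl compound is a 2.5-fold higher number from compound 1 to compound 3 (0.40 log units; beyond the scatter), while the step to the 4-bromobenzyl compound is a 1.7-fold higher number from compound 1 to compound 4 (0.24 log units; within the scatter), and compound 4 also stays close to the cyclohexyl compound, with a 1.7-fold lower number from compound 2 to compound 4 (0.22 log units; within the scatter). Nothing measured on these compounds speaks to the reason for this result.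

The compounds shown leave open whether a fluoro, a methoxy or a carboxylic acid in this same place on the benzyl ring would stay within the scatter of compound 3, and whether a benzyl ring with no halogen at all would do so. Also open, on these data alone, is whether a phenethyl group on that nitrogen, with its longer chain, would keep the number in the range of compound 3 and compound 4.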